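Fluoro for chloro on the aryl ether of compound 1

The source may report more compounds than this note shows. Statements on the series, on what has been measured and on what is new or still open speak of the compounds shown alone.

Within the data shown here, compound 1 `NC1=NC2(CCOCC2)N(OCCCOc2ccc(Cl)cc2)C(N)=N1` gives 33.6 nM in an assay on isolated protein for inhibition of Dihydrofolate reductase (Homo sapiens), read by spectrophotometry, using NADPH, with stated times of 5 s and 6 min (a lower number here means a stronger inhibitor, a higher number a weaker inhibitor), the higher of the two numbers known here. Compound 2 `NC1=NC2(CCSCC2)N(OCCCOc2ccc(Br)cc2)C(N)=N1` gives 6.46 nM in this assay, a lower number beyond the usual scatter. Compound 3 `NC1=NC2(CCOCC2)N(OCCCOc2ccc(F)cc2)C(N)=N1` differs from compound 1 by fluoro in place of chloro on an aromatic carbon, on an aromatic carbon of a six-membered aromatic ring of carbon only. Among the measured compounds shown here, no pair of measured compounds isolates this exchange. Compound 3 is expected to give a somewhat higher number, a step of a 2.4-fold higher number from compound 1 to compound 3 (0.38 log units; beyond the scatter) that may only just exceed the scatter. Compound 3 is estimated at 80 nM, between 30 nM and 220 nM.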

Compound 3, half-maximal inhibitory concentration: 46.6 nM
Compound 3: middle estimate off by 1.7-fold (0.23 log units), on the high side, within the range that was stated.
By their numbers in this assay, from the lowest: compound 2; then compounds 1 and 3 (each within the scatter of the next).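

Fluoro in place of chloro, on an aromatic carbon para to a large group, gives a 1.4-fold higher number from compound 1 to compound 3 (0.14 log units; within the scatter) in this assay. Among these compounds, this is the first reading that isolates this position, and it shows that compound 1 and compound 3 cannot be told apart in this assay, so the exchange of these two halogens leaves the number within the scatter. Nothing measured here speaks to what lies behind this result. Going by these compounds, whether methoxy, nitrile or an amine on the same aromatic carbon would keep the number in this range stays open.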